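This account rests on a few compounds, and the source may have more. Where it says the series, first, only, none or still open, it means among the compounds named here.

Measured in an ADME assay on HepG2 cells (Homo sapiens) for cytotoxicity, with a stated time of 72 h; a higher number here means that more compound is needed for the effect, a lower number that less compound is needed:

Compound 1 `COc1ccc(NC(=O)Nc2cc(C)nc3ccccc23)cc1OC`: > 25000 nM
Compound 2 `COc1ccc(NC(=O)Nc2cc(C)nc3ccccc23)cc1F`: > 25000 nM

Compound 1 stands at > 25000 nM, which is a limit of the assay and not a number. Compound 2 gives > 25000 nM, which is also a limit. The whole picture so far is the limit of > 25000 nM in this assay, at which 2 of the 2 values shown sit, so no exact value is available as a starting point.

Compound 3 `COc1cccc(NC(=O)Nc2cc(C)nc3ccccc23)c1` differs from compound 1 by one change: hydrogen in place of methoxy on an aromatic carbon. In words, hydrogen takes the place of methoxy on an aromatic carbon. Among the compounds with values here, the one measured step that bears on this also removes a methoxy group: a step that the two limits leave unreadable from compound 1 to compound 2. Its size cannot be read, so it offers no size to carry over.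

In this assay, no step beyond the usual scatter is expected, and another limit is the most likely report. This expectation rests on compound 1, whose > 25000 nM is a limit. For compound 3 the estimated value is 30000 nM, with an expected range from 15000 nM to 60000 nM. This estimate means an expected step that the limit leaves unreadable from compound 1 to compound 3.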

Compound 3, half-maximal effective concentration: > 25000 nM
Compound 3 gave a limit, no number (the forecaster's own chance of this, stated with the estimate: 85%); the middle value is on the limit's open side.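

In this assay compound 3 gives > 25000 nM, which is a limit of the assay and not a number. Within the data shown here, compound 1 also stands at a limit, so no step from compound 1 to compound 3 can be read. The overall picture is unchanged: the limit of > 25000 nM in this assay, at which 3 of the 3 values shown sit. The compounds shown leave open what exact concentration any of them needs for the effect, and whether replacing methoxy changes it.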